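A few compounds are considered here, and "the series" means these few. Any claim that something is new, unique, unknown or untested is made for them only; others in the source may bear on it.

Three compounds have so far been run in a functional assay on the whole organism for antagonist activity, with Rattus norvegicus as the target; on this read-out higher numbers stand for an effect only at larger amounts of compound and lower numbers for an effect already at smaller amounts. Compound 1 `O=C(Nc1ccc(C(=O)N2CCCCc3sccc32)cc1OCCCC(=O)N1CCC(N2CCCCC2)CC1)c1ccccc1-c1ccccc1` gives 0.03 mg/kg. Compound 3 `CN(C)CCN1CCCN(C(=O)c2ccc(NC(=O)c3ccccc3-c3ccccc3)cc2)c2ccsc21` gives 0.31 mg/kg. Compound 2 `CN1CCN(CCCCOc2cc(C(=O)N3CCCCc4sccc43)ccc2NC(=O)c2ccccc2-c2ccccc2)CC1` is reported only as < 0.01 mg/kg, which is a limit of the assay and not a number; this is the limit of < 0.01 mg/kg in this assay, at which 1 of the 3 values shown sits. Compound 4 `CN1CCN(C(=O)CCCOc2cc(C(=O)N3CCCCc4sccc43)ccc2NC(=O)c2ccccc2-c2ccccc2)CC1` has not yet been tested in this assay. It differs from compound 2 in one place: (4-methylpiperazin-1-yl)carbonyl in place of (4-methylpiperazin-1-yl)methyl on a saturated chain carbon, three bonds along the chain from an oxygen on an aromatic ring. No pair of measured compounds differs in a single position, so the size of such a step is not shown directly, and compound 2 offers only a limit to measure from. Compound 4 is expected to give about 0.02 mg/kg, with a likely range from 0.005 mg/kg to 0.08 mg/kg. The expected step is therefore an at least 2.0-fold higher number from compound 2 to compound 4 (0.30 log units; that floor lies within the scatter), a loss somewhat beyond the scatter.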

Compound 4, dose for 50% inhibition: 0.03 mg/kg
Beside the measured number, compound 4's estimate is 1.5-fold (0.18 log units) below it, within the range that was stated.
By their numbers in this assay, from the lowest: compounds 1 and 4 (each within the scatter of the next); then compound 3. At a limit, below all of these: compound 2.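

In this assay, among the compounds shown here, (4-methylpiperazin-1-yl)carbonyl in place of (4-methylpiperazin-1-yl)methyl on this saturated chain carbon gives an at least 3.0-fold higher number from compound 2 to compound 4 (0.47 log units; beyond the scatter), a step at this position that no earlier pair showed. The value of compound 2 is a limit of the assay, so this step gives only a floor: the limit of < 0.01 mg/kg in this assay, at which 1 of the 4 values shown sits.

With the carbonyl kept, 4-methylpiperazin-1-yl in place of 4-(piperidin-1-yl)piperidin-1-yl on the carbonyl carbon gives no change at the digits printed from compound 1 to compound 4 (within the scatter). From the compounds shown here alone, the true size of the step to the carbonyl remains open. So does whether a morpholine or a dimethylamino group on that carbonyl would read the same.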